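Hydroxymethyl for trifluoromethyl on a biphenyl amide

The compounds below may be only part of what the source reports. "The series", "measured", "known", "first", "only" and "open" are said of these compounds alone.

Compound 1, `N[C@H](CN(C(=O)[C@@H]1C[C@H]1c1ccccc1)c1ccc(-c2ccccc2)cc1)C1CCCCC1`, in a functional assay for agonist activity at G protein-coupled receptor 88 (Homo sapiens), read by HTRF and cAMP accumulation; on this read-out higher numbers stand for an effect only at larger amounts of compound and lower numbers for an effect already at smaller amounts: 0.66 nM
Compound 2, `CC[C@H](C)[C@H](N)CN(C(=O)[C@@H]1C[C@H]1c1ccc(Cl)cc1)c1ccc(-c2ccccc2)cc1`, in this assay: 4300 nM
Compound 3, `CC[C@H](C)[C@H](N)CN(C(=O)[C@@H]1C[C@H]1c1ccccc1)c1ccc(-c2ccc(C(F)(F)F)cc2)cc1`, in this assay: 340 nM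

Among these three numbers compound 3 stands second highest. Its nearest neighbour is compound 2, whose number is higher by a margin beyond the usual scatter, and its furthest is compound 1, whose number is lower by a much wider margin, also beyond the scatter. Among the compounds with values here, the three compounds differ from one another in more than one place, so no single step between them can be isolated.

Compound 4, `CC[C@H](C)[C@H](N)CN(C(=O)[C@@H]1C[C@H]1c1ccccc1)c1ccc(-c2ccc(CO)cc2)cc1`, is the next member. It differs from compound 3 in one place only: hydroxymethyl in place of trifluoromethyl on an aromatic carbon. Cut one bond further out, the same difference reads 4-(trifluoromethyl)phenyl to 4-(hydroxymethyl)phenyl, the group standing para to a large group on the outer ring.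

Within the data shown here, no measured pair shows this change, and the three measured compounds give no step that isolates the outer ring. The expectation for compound 4 is therefore held loosely: a step from compound 3 to compound 4 of a 1.8-fold higher number from compound 3 to compound 4 (0.25 log units; within the scatter) is expected, towards a somewhat higher number. In this assay compound 4 is estimated at 600 nM, with a range from 120 nM to 3000 nM.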

Compound 4, half-maximal effective concentration: 1100 nM
Compound 4: middle estimate off by 1.8-fold (0.26 log units), on the low side; the range from low to high includes it.
By their numbers in this assay, from the lowest: compound 1; then compound 3; then compound 4; then compound 2.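

Within the data shown here, this position on the outer ring can now be read on its own for the first time, since the earlier compounds differed from one another in more than one place. In this assay, hydroxymethyl in place of trifluoromethyl, para to a large group, gives a 3.2-fold higher number from compound 3 to compound 4 (0.51 log units; beyond the scatter), so the group at this position moves the number by more than the usual scatter. The group that enters carries a hydrogen-bond donor and a hydrogen-bond acceptor and the group that leaves carries neither, but this is a single pair that also differs in heavy-atom count, and nothing shown gives a reason for the step or separates those differences from one another.

The compounds shown leave open how either group compares with plain hydrogen at this position, so it cannot be said whether trifluoromethyl raises the number, hydroxymethyl raises it, or both do. They also leave open how an aminomethyl group, a methoxymethyl group or a carboxylic acid at the same position would read, and whether this step would hold on the cyclohexyl side chain of compound 1.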